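Moving the fluorine around the ring of an amidoxime inhibitor

This account rests on a few compounds, and the source may have more. Where it says the series, first, only, none or still open, it means among the compounds named here.

This account concerns a small set of nitro-substituted amidoximes built on a shared core, tested in an assay on isolated protein for inhibition of Indoleamine 2,3-dioxygenase 1 (Homo sapiens), read by spectrophotometry, with a stated time of 1 h; on this read-out higher numbers stand for weaker inhibition and lower numbers for stronger inhibition. The parent, compound 1 `O=[N+]([O-])c1ccc(N/C(=N\O)c2ccccc2)c2nonc12`, gives 268 nM. Compound 2 `O=[N+]([O-])c1ccc(N/C(=N\O)c2ccccc2F)c2nonc12` gives 63 nM, and compound 3 `O=[N+]([O-])c1ccc(N/C(=N\O)c2ccccc2Br)c2nonc12` gives 80 nM. Compound 2 has the lowest number of the three: its nearest neighbour is compound 3, within the scatter, and the furthest is compound 1, with the step of a 4.3-fold lower number from compound 1 to compound 2 (0.63 log units; beyond the scatter) lying beyond it. Compound 3 likewise improves on the parent, a 3.4-fold lower number from compound 1 to compound 3 (0.53 log units; beyond the scatter), while the change between compound 2 and compound 3, a 1.3-fold higher number from compound 2 to compound 3 (0.10 log units; within the scatter), is within the scatter.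

Compound 4 `O=[N+]([O-])c1ccc(N/C(=N\O)c2ccc(F)cc2)c2nonc12` differs from compound 2 as follows: 4-fluorophenyl in place of 2-fluorophenyl on a carbon with a double bond to nitrogen. Among the measured compounds shown here, no measured step bears directly on this change, since both halogen steps, a 4.3-fold lower number from compound 1 to compound 2 (0.63 log units; beyond the scatter) and a 3.4-fold lower number from compound 1 to compound 3 (0.53 log units; beyond the scatter), place the halogen in the same position. The gain seen in compound 2 may therefore not carry over fully, and a step back toward compound 1 is expected. Compound 4 is estimated at 150 nM (range 50 nM to 450 nM), a step of a 2.4-fold higher number from compound 2 to compound 4 (0.38 log units; beyond the scatter) from compound 2 in this assay.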

Compound 4, half-maximal inhibitory concentration: 100 nM
Estimate against measurement, compound 4: 1.5-fold (0.18 log units) above; the range from low to high includes it.
By their numbers in this assay, from the lowest: compounds 2, 3 and 4 (each within the scatter of the next); then compound 1.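

In this assay the exchange of 2-fluorophenyl for 4-fluorophenyl on the carbon with a double bond to nitrogen gives a small step (a 1.6-fold higher number from compound 2 to compound 4 (0.20 log units; within the scatter)), so among these compounds the read-out does not separate the two places for the fluorine. Fluoro in place of hydrogen still helps when the group is 4-fluorophenyl (a 2.7-fold lower number from compound 1 to compound 4 (0.43 log units; beyond the scatter)), and this gain lies beyond the scatter, while the comparison with 2-bromophenyl (a 1.3-fold higher number from compound 3 to compound 4 (0.10 log units; within the scatter)) lies within it. No evidence is at hand on what lies behind these numbers.

The compounds shown leave open whether a group other than a halogen on this phenyl ring, such as methoxy, nitrile or an amine, would give a similar number. They also leave open how chloro would compare with fluoro and bromo.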